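A few compounds are considered here, and "the series" means these few. Any claim that something is new, unique, unknown or untested is made for them only; others in the source may bear on it.

Measured compounds in an ADME assay on HEL cells (Homo sapiens) for cytotoxicity, with a stated time of 3 days; on this read-out lower numbers stand for higher toxicity in this test and higher numbers for lower toxicity in this test:
Compound 1, `Cc1cc(-c2ccoc2)cn2c(CSCCc3ccccc3)cnc12`, gives 12 ug/mL.
Compound 2, `Cc1cc(N2CCCC2)cn2c(CSCCc3ccccc3)cnc12`, gives 12 ug/mL.
Compound 3, `Cc1cc(-c2ccoc2)c2ncc(CSCCc3ccccc3)n2c1`, gives 64 ug/mL.

Compound 1 and compound 2 share one core and differ in a single place: pyrrolidin-1-yl in place of furan-3-yl on an aromatic carbon. In this assay this change produced no change at the digits printed from compound 1 to compound 2 (within the scatter), so the two numbers cannot be ordered. Compound 3 is built from the same atoms as compound 1, joined differently; how the two cores differ is not broken down here. Among the three numbers compound 3 stands highest, and its distance from compound 1, as from compound 2, lies beyond the scatter.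

Compound 4, `Cc1cc(N2CCCC2)c2ncc(CSCCc3ccccc3)n2c1`, has not yet been measured. It differs from compound 3 by pyrrolidin-1-yl in place of furan-3-yl on an aromatic carbon. This is the same kind of change as from compound 1 to compound 2, but the surroundings are not identical: in compound 2 the group sits para to a fused ring, whereas in compound 4 it sits ortho to a fused ring.

Because the same kind of change gave no change at the digits printed from compound 1 to compound 2 (within the scatter), the step from compound 3 to compound 4 is expected to be small, a 1.1-fold lower number from compound 3 to compound 4 (0.03 log units; within the scatter). Compound 4 is therefore estimated at 60 ug/mL in this assay. The expected range for compound 4 runs from 25 ug/mL to 130 ug/mL, the width reflecting that the surroundings of the change differ from those in compound 1 and compound 2.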

Compound 4, half-maximal cytotoxic concentration: > 100 ug/mL
Compound 4: a limit, no number; the forecaster's own chance of this, stated with the estimate: 15%; middle value at least 1.6-fold (0.22 log units) away from the limit.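

In this assay compound 4 gives > 100 ug/mL, which is a limit of the assay and not a number. Placing pyrrolidin-1-yl where furan-3-yl stood on the aromatic carbon gives an at least 1.5-fold higher number from compound 3 to compound 4 (0.19 log units; that floor lies within the scatter), so the reading fixes only a floor for this step and not its size. The result neither shows that the change carries over unaltered from the core of compound 1 to the core of compound 3 nor shows that the two cores respond to it differently: the same change on two cores in this assay, no change at the digits printed (within the scatter) from compound 1 to compound 2 and an at least 1.5-fold higher number (0.19 log units; that floor lies within the scatter) from compound 3 to compound 4; the limit leaves it open whether they differ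

The compounds shown leave open how other groups on the same aromatic carbon would read on each of the two cores, for example an open-chain amine such as dimethylamino, a six-membered ring such as morpholine, or a phenyl ring in place of furan-3-yl. They also leave open whether the picture would hold if the chain bearing the sulfur and the phenyl ring, which is the same in all four compounds, were replaced by a shorter chain or carried a substituent such as fluorine on its phenyl ring.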